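Solubility of a quinolinyl-azetidinyloxy pyrazine series: aryl replacement

The compounds below may be only part of what the source reports. "The series", "measured", "known", "first", "only" and "open" are said of these compounds alone.

Measured compounds:
compound 1 `OCCC1CCN(c2nccnc2OC2CN(c3ccc4ccccc4n3)C2)CC1`, 84000 nM
compound 2 `OC1CCN(c2nccnc2OC2CN(c3ccc4ccccc4n3)C2)CC1`, 99000 nM
compound 3 `OCc1cccc(-c2nccnc2OC2CN(c3ccc4ccccc4n3)C2)c1`, 29000 nM

In a physicochemical assay for solubility, in phosphate buffer, at pH 7.4 (on this read-out higher numbers stand for higher solubility and lower numbers for lower solubility), compound 1 gives 84000 nM, the second highest of the three numbers. Compound 2 sits nearest, a 1.2-fold higher number from compound 1 to compound 2 (0.07 log units; within the scatter), so the two cannot be told apart. Compound 3 stands furthest away, a 2.9-fold lower number from compound 1 to compound 3 (0.46 log units; beyond the scatter), and compound 2 shows the same direction, a 3.4-fold lower number from compound 2 to compound 3 (0.53 log units; beyond the scatter).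

Compound 4 `Cc1ccc(-c2nccnc2OC2CN(c3ccc4ccccc4n3)C2)cc1` has not yet been measured in this assay. It differs from compound 1 as follows: 4-methylphenyl in place of 4-(2-hydroxyethyl)piperidin-1-yl on an aromatic carbon. The step from compound 1 to compound 3 bears on this: an aromatic ring in place of the saturated ring gave a modest fall. In compound 4 the ring that enters carries a methyl and no hydroxy, unlike compound 3, so the fall is expected to be at least as large and probably larger. Compound 4 is expected to give 8000 nM, within 2000 nM to 30000 nM, the estimated step being an 11-fold lower number from compound 1 to compound 4 (1.02 log units; beyond the scatter).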

Compound 4, solubility: < 1000 nM
Compound 4: only a limit was reported (the forecaster's own chance of this, stated with the estimate: 10%); middle value at least 8.0-fold (0.90 log units) away from the limit.
By their numbers in this assay, from the lowest: compound 3; then compounds 1 and 2 (each within the scatter of the next). At a limit, below all of these: compound 4.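

In this assay compound 4 gives < 1000 nM, which is a limit of the assay and not a number, and it is the only limit among the values shown: the limit of < 1000 nM in this assay, at which 1 of the 4 values shown sits.

Among these compounds, at this position, on an aromatic carbon next to the ring nitrogen, the steps to the 4-methylphenyl compound are large, with an at least 84-fold lower number from compound 1 to compound 4 (1.92 log units; beyond the scatter) and an at least 99-fold lower number from compound 2 to compound 4 (1.99 log units; beyond the scatter), where the earlier steps to compound 3 were only modest. Between the two aromatic compounds the result is an at least 29-fold lower number from compound 3 to compound 4 (1.46 log units; beyond the scatter), so an aromatic ring here does not by itself set the size of the fall, and what the ring carries matters.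

The limit leaves the true size of these steps open. The step from compound 3 to compound 4 changes both the substituent and where it sits, so a 4-(hydroxymethyl)phenyl or an aminomethyl-bearing phenyl ring would be needed to separate the two.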